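One Ring Traded for Another on Compound 1

This account rests on a few compounds, and the source may have more. Where it says the series, first, only, none or still open, it means among the compounds named here.

Compound 1 `Cc1cc(Cl)cc(-c2ccnc3cc(CN4C(=O)C5C(C4=O)C5(C)C)sc23)c1C[C@@H]1CNCCO1` is the stronger of the two compounds measured in an assay on isolated protein for inhibition of ubiquitin carboxyl-terminal hydrolase 7 (Homo sapiens), read by fluorescence, with stated times of 30 min and 1 h; a lower number here means a stronger inhibitor, a higher number a weaker inhibitor: compound 1 gives 0.44 nM, while compound 2 `O=C([C@H]1Cc2cc(Cl)cc(-c3ccnc4ccsc34)c2O1)N1CCNCC1` gives 90 nM, a gap well beyond the scatter of this assay. Compound 3 `Cc1cc(Cl)cc(-c2ccnc3cc(CN4C(=O)C5C(C4=O)C5(C)C)sc23)c1CC1CCCNC1` has not yet been measured. It differs from compound 1 in one place: piperidin-3-yl in place of morpholin-2-yl on a saturated chain carbon bound to an aromatic carbon. Among the measured compounds shown here, no measured pair shows this change, so its effect is unknown; the change is expected to move the number little, if at all, within the scatter: a 1.4-fold higher number from compound 1 to compound 3 (0.13 log units; within the scatter). Compound 3 is therefore expected to give about 0.6 nM, somewhere between 0.2 nM and 2 nM.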

Compound 3, half-maximal inhibitory concentration: 1.3 nM
Estimate against measurement, compound 3: 2.2-fold (0.34 log units) below, within the range that was stated.
By their numbers in this assay, from the lowest: compound 1; then compound 3; then compound 2.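

In this assay, piperidin-3-yl in place of morpholin-2-yl on a saturated chain carbon bound to an aromatic carbon gives a 3.0-fold higher number from compound 1 to compound 3 (0.47 log units; beyond the scatter), so this position does respond to the ring, though only modestly. The swap takes away a ring oxygen, a hydrogen-bond acceptor and the defined stereocentre all at once, and the step cannot be divided among them. Nothing available explains the step. Still open, from the compounds shown here alone, is how a pyrrolidin-3-yl ring or an open-chain amine would fare at this place.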